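Cyclic amine in place of a chain amine on the core

This account rests on a few compounds, and the source may have more. Where it says the series, first, only, none or still open, it means among the compounds named here.

In a functional assay on SK-BR-3 cells (Homo sapiens) for antiproliferative activity, read by MTT assay, with a stated time of 72 h (on this read-out higher numbers stand for weaker inhibition and lower numbers for stronger inhibition), three compounds on a shared core have been measured. Compound 1 `CCNc1cc(C)c2cc(NC(=O)c3ccc(Cl)c(Cl)c3)ccc2n1` gives 28200 nM. Compound 2 `CCN1CCN(c2cc(C)c3cc(NC(=O)c4ccc(F)c(F)c4)ccc3n2)CC1` gives 1980 nM. Compound 3 `CCN(CC)CCNc1cc(C)c2cc(NC(=O)c3ccc(Cl)c(Cl)c3)ccc2n1` gives 3710 nM, the second highest of the three numbers; its value and that of compound 2 lie within the scatter of each other, while the step from compound 1 was a 7.6-fold lower number from compound 1 to compound 3 (0.88 log units; beyond the scatter). Compound 4 `CCN1CCN(c2cc(C)c3cc(NC(=O)c4ccc(Cl)c(Cl)c4)ccc3n2)CC1` is not yet measured; it differs from compound 3 by 4-ethylpiperazin-1-yl in place of (2-(diethylamino)ethyl)amino on an aromatic carbon. Within the data shown here, no measured step changes exactly this group, so the only bearing comes from compound 2, which carries the same 4-ethylpiperazin-1-yl group and differs from compound 4 only in the halogens on the benzamide, and from the step from compound 1 to compound 3, which shows that this side of the core tolerates a basic chain amine. The step from compound 3 to compound 4 is therefore expected to be a 1.5-fold lower number from compound 3 to compound 4 (0.17 log units; within the scatter), within the scatter. In this assay compound 4 is expected to give about 2500 nM, between 900 nM and 7000 nM.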

Compound 4, half-maximal inhibitory concentration in the SK-BR-3 assay: 2160 nM
Estimate against measurement, compound 4: 1.2-fold (0.06 log units) above, within the range that was stated.
By their numbers in the SK-BR-3 assay, from the lowest: compounds 2, 4 and 3 (each within the scatter of the next); then compound 1.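

In the SK-BR-3 assay, closing the chain amine into 4-ethylpiperazin-1-yl on this aromatic carbon does not separate the two groups, with a 1.7-fold lower number from compound 3 to compound 4 (0.23 log units; within the scatter), and 3,4-dichlorophenyl in place of 3,4-difluorophenyl on the carbonyl carbon does not separate compound 2 and compound 4 either, with a 1.1-fold higher number from compound 2 to compound 4 (0.04 log units; within the scatter). Against the ethylamino group the same ring gives a 13-fold lower number from compound 1 to compound 4 (1.12 log units; beyond the scatter), so at this position the 4-ethylpiperazin-1-yl group and the (2-(diethylamino)ethyl)amino group both stand well apart from ethylamino. The two groups do part in a physicochemical assay for solubility (a lower number here means a less soluble compound, a higher number a more soluble compound), where compound 3 gives 95.2 ug/mL and compound 4 gives 11.3 ug/mL. The ring form is clearly the less soluble: the measured solubility of compound 3, 95.2 ug/mL, and of compound 4, 11.3 ug/mL, an 8.4-fold lower number (0.93 log units; beyond the scatter)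

From the compounds shown here alone, it remains open whether a morpholine or a piperidine on this aromatic carbon would match these numbers in the SK-BR-3 assay. Also open, going by these compounds, is where such rings, or a shorter aminoalkyl chain, would fall in the physicochemical assay.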